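Nitrooxy for Methyl on the Sulfonyl Aryl Ring

The compounds below may be only part of what the source reports. "The series", "measured", "known", "first", "only" and "open" are said of these compounds alone.

Compound 1 `Cc1ccc(S(=O)(=O)N2C/C(=C\c3ccccc3F)C(=O)/C(=C/c3ccccc3F)C2)cc1` gives in a functional assay on HepG2 cells (Homo sapiens) for cytotoxicity, read by MTT assay, with a stated time of 24 h (a higher number here means a weaker inhibitor, a lower number a stronger inhibitor), a value of 14200 nM. Compound 2 `O=C1/C(=C/c2ccccc2F)CN(S(=O)(=O)c2ccc(O[N+](=O)[O-])cc2)C/C1=C\c1ccccc1F` gives 16500 nM in this assay. The change between them, (nitrooxy in place of methyl on an aromatic carbon), made a step of a 1.2-fold higher number from compound 1 to compound 2 (0.07 log units; within the scatter).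

Compound 3 `Cc1ccc(S(=O)(=O)N2C/C(=C\c3cccc(F)c3)C(=O)/C(=C/c3cccc(F)c3)C2)cc1` gives 3500 nM in this assay, the lowest number of the three; compound 1 stands nearest to it and compound 2 furthest, both beyond the scatter. The difference between the cores of compound 3 and compound 1 is not broken down here; the two hold the same atoms joined differently.

Compound 4 `O=C1/C(=C/c2cccc(F)c2)CN(S(=O)(=O)c2ccc(O[N+](=O)[O-])cc2)C/C1=C\c1cccc(F)c1` has not yet been measured in this assay. It differs from compound 3 by nitrooxy in place of methyl on an aromatic carbon, the same change as that from compound 1 to compound 2, at the same kind of place. The step from compound 3 to compound 4 is therefore expected to be about a 1.2-fold higher number from compound 3 to compound 4 (0.08 log units; within the scatter), resting on the step of a 1.2-fold higher number from compound 1 to compound 2 (0.07 log units; within the scatter). Compound 4 is thus estimated to give 4200 nM in this assay, between 2200 nM and 8500 nM.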

Compound 4, half-maximal inhibitory concentration: 8100 nM
For compound 4 the middle estimate is 1.9-fold (0.29 log units) below the measured one; the range from low to high includes it.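

In this assay, nitrooxy in place of methyl on an aromatic carbon gave a 2.3-fold higher number from compound 3 to compound 4 (0.36 log units; beyond the scatter), a step beyond the scatter on this core, whereas the earlier step on the core of compound 1 lay within it. Even so, the two steps cannot be told apart: the same change on two cores in this assay, a 1.2-fold higher number (0.07 log units; within the scatter) from compound 1 to compound 2 and a 2.3-fold higher number (0.36 log units; beyond the scatter) from compound 3 to compound 4, 2.0-fold (0.30 log units) apart, within the scatter of two such steps. This shows that the change carried from one core to the other without a measurable difference in its effect, but it does not show that the step is truly larger on the core of compound 3, and two cores give no basis for predicting its size on any further core.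

Only methyl and nitrooxy appear in this place, so the compounds shown leave open whether the step belongs to nitrooxy itself or would also arise with another group there, such as a methoxy group, an amine or a carboxylic acid. They also leave open how the change behaves in any assay other than this assay.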